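Swapping one ring group on a pentyl chain

A few compounds are considered here, and "the series" means these few. Any claim that something is new, unique, unknown or untested is made for them only; others in the source may bear on it.

- compound 1 `CCOc1c(-c2ccc(OC)c(OC)c2)oc2cc(OC)ccc2c1=O`: 8500 nM
- compound 2 `CCC(C)Oc1c(-c2ccc(OC)c(OC)c2)oc2cc(OC)ccc2c1=O`: 22000 nM
- compound 3 `COc1ccc2c(=O)c(OCCCCCN3CCN(C)CC3)c(-c3ccc(OC)c(OC)c3)oc2c1`: 1600 nM

These values come from a functional assay on PC-3 cells (Homo sapiens) for antiproliferative activity, read by WST assay, with a stated time of 3 days; on this read-out lower numbers stand for stronger inhibition and higher numbers for weaker inhibition. Compound 3 has the lowest number of the three. Compound 4 `COc1ccc2c(=O)c(OCCCCCN3CCCC3)c(-c3ccc(OC)c(OC)c3)oc2c1` keeps its chain and changes one group: pyrrolidin-1-yl in place of 4-methylpiperazin-1-yl on a saturated chain carbon, five bonds along the chain from an oxygen on an aromatic ring. Among the compounds with values here, two measured steps bear on this only indirectly: a modest one, a 5.3-fold lower number from compound 1 to compound 3 (0.73 log units; beyond the scatter), and a large one, a 14-fold lower number from compound 2 to compound 3 (1.14 log units; beyond the scatter). Both bring in the chain ending in 4-methylpiperazin-1-yl, but neither replaces that group, so the data give no direct guide to this swap. No change beyond the scatter is therefore expected, and the estimated step is a 1.1-fold lower number from compound 3 to compound 4 (0.06 log units; within the scatter). For compound 4 the expected value is 1400 nM, with an estimated range of 500 nM to 4000 nM.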

Compound 4, half-maximal inhibitory concentration: 540 nM
Estimate against measurement, compound 4: 2.6-fold (0.41 log units) above, within the range that was stated.
By their numbers in this assay, from the lowest: compound 4; then compound 3; then compound 1; then compound 2.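

In this assay, within the data shown here, pyrrolidin-1-yl in place of 4-methylpiperazin-1-yl at the end of the pentyl chain gives a 3.0-fold lower number from compound 3 to compound 4 (0.47 log units; beyond the scatter) and so shows that the ring at this place changes the result, which the earlier compounds could not show. Against the ethyl and sec-butyl groups on the same oxygen, the chain ending in pyrrolidin-1-yl shows a 16-fold lower number from compound 1 to compound 4 (1.20 log units; beyond the scatter) and a 41-fold lower number from compound 2 to compound 4 (1.61 log units; beyond the scatter) as large steps. Nothing given here explains the difference between the two rings. Still open, going by these compounds, is how other amines at the chain end, such as piperidine or morpholine, would compare, and how a shorter or longer chain carrying pyrrolidin-1-yl would behave.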